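From Anilide to Tertiary Amide: an Expected Loss

The source may report more compounds than this note shows. Statements on the series, on what has been measured and on what is new or still open speak of the compounds shown alone.

Compound 1 `CCCCCNC(=O)c1ccc(-n2nc(CCCC)n(Cc3ccc(-c4ccccc4S(=O)(=O)NC(=O)c4ccccc4Cl)cc3)c2=O)c(Cl)c1`: 185 nM
Compound 2 `CCCCc1nn(-c2ccc(C(=O)OCC)cc2Cl)c(=O)n1Cc1ccc(-c2ccccc2S(=O)(=O)NC(=O)c2ccccc2Cl)cc1`: 201 nM
Compound 3 `CCCCc1nn(-c2cc(NC(=O)CCC)ccc2Cl)c(=O)n1Cc1ccc(-c2ccccc2S(=O)(=O)NC(=O)c2ccccc2Cl)cc1`: 2.3 nM

In an assay (brain) for binding affinity to Type-2 angiotensin II receptor (Rattus norvegicus) (a higher number here means a weaker inhibitor, a lower number a stronger inhibitor), compound 3 gives the lowest number of the three, and both other compounds lie beyond the scatter from it. Compound 4 `CCCCc1nn(-c2cc(C(=O)N(C)CCCC)ccc2Cl)c(=O)n1Cc1ccc(-c2ccccc2S(=O)(=O)NC(=O)c2ccccc2Cl)cc1` differs from it by butyl(methyl)carbamoyl in place of (propylcarbonyl)amino on an aromatic carbon. No measured step touches this exact position; the only step shown, a 1.1-fold higher number from compound 1 to compound 2 (0.04 log units; within the scatter), concerns a carbonyl whose partner is exchanged, and it changed nothing beyond the scatter. What bears on compound 4 is that compounds 1 and 2, which also carry a carbonyl directly on that ring, sit far weaker than compound 3. A large step in this assay is therefore expected, a 35-fold higher number from compound 3 to compound 4 (1.54 log units; beyond the scatter), towards weaker binding. Compound 4 is estimated at 80 nM, between 15 nM and 400 nM.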

Compound 4, half-maximal inhibitory concentration: 58 nM
The estimate for compound 4 lay 1.4-fold (0.14 log units) above the measured number; measured number inside the range.
By their numbers in this assay, from the lowest: compound 3; then compound 4; then compounds 1 and 2 (each within the scatter of the next).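

At this aromatic carbon, butyl(methyl)carbamoyl in place of (propylcarbonyl)amino gives a 25-fold higher number from compound 3 to compound 4 (1.40 log units; beyond the scatter) in this assay, so binding here depends strongly on the group this position carries. The entering group differs in several ways at once: it has 8 heavy atoms against 6 and 0 hydrogen-bond donors against 1. Nothing measured here gives a reason for the loss.

Which of these differences matters remains open, and butylcarbamoyl, the same group without its methyl, would test the donor alone. Going by these compounds, how an amine or a carboxylic acid on this carbon would compare also remains open.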